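The source may report more compounds than this note shows. Statements on the series, on what has been measured and on what is new or still open speak of the compounds shown alone.

Compound 3 `COc1cccc(C(=O)Nc2cccc(-c3oc4cc(-c5ccc(F)cc5)ccc4c(=O)c3O)c2)c1` gives 12500 nM in a functional assay on GTL 16 cells for antiproliferative activity against GTL 16 cell line (Homo sapiens), read by CCK-8 assay, with a stated time of 72 h (on this read-out lower numbers stand for stronger inhibition and higher numbers for weaker inhibition), the second highest of the three numbers. Compound 2 `O=C(Nc1cccc(-c2oc3cc(-c4ccc(F)cc4)ccc3c(=O)c2O)c1)c1ccc(F)cc1F` gives 9640 nM and compound 1 `COc1ccc(C(=O)Nc2cccc(-c3oc4cc(-c5ccc(F)cc5)ccc4c(=O)c3O)c2)cc1` gives 21100 nM; both gaps to compound 3 stay within the scatter (a 1.3-fold higher number from compound 2 to compound 3 (0.11 log units; within the scatter); a 1.7-fold lower number from compound 1 to compound 3 (0.23 log units; within the scatter)). Within the data shown here, the only step beyond the scatter is a 2.2-fold lower number from compound 1 to compound 2 (0.34 log units; beyond the scatter). Compound 4 `COc1ccc(C(=O)Nc2cccc(-c3oc4cc(-c5ccc(F)cc5)ccc4c(=O)c3O)c2)c(F)c1` carries the change (2-fluoro-4-methoxyphenyl in place of 3-methoxyphenyl on a carbonyl carbon). Relative to the group of compound 1 the entering group adds a single fluorine, so the steps that bear on it, a 1.7-fold lower number from compound 1 to compound 3 (0.23 log units; within the scatter) and a 2.2-fold lower number from compound 1 to compound 2 (0.34 log units; beyond the scatter), are small and point in different directions. For compound 4 a step of a 1.0-fold lower number from compound 3 to compound 4 (0.02 log units; within the scatter) is expected, within the scatter. Compound 4 is therefore estimated at 12000 nM in this assay, ranging from 4000 nM to 36000 nM.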

Compound 4, half-maximal inhibitory concentration: 15300 nM
Compound 4: middle estimate off by 1.3-fold (0.11 log units), on the low side; measured number inside the range.
By their numbers in this assay, from the lowest: compounds 2, 3, 4 and 1 (each within the scatter of the next, the first and the last beyond it).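

In this assay, fluoro in place of hydrogen on an aromatic carbon stays within the scatter: a 1.4-fold lower number from compound 1 to compound 4 (0.14 log units; within the scatter). So do the exchange of 3-methoxyphenyl for 2-fluoro-4-methoxyphenyl on the carbonyl carbon, a 1.2-fold higher number from compound 3 to compound 4 (0.09 log units; within the scatter), and methoxy in place of fluoro on an aromatic carbon, a 1.6-fold higher number from compound 2 to compound 4 (0.20 log units; within the scatter). Compound 4 therefore adds no new step beyond the scatter, and the gap between compound 1 and compound 2 remains the only one.

As far as these compounds go, the effect of an amine or a carboxylic acid on this phenyl group stays open. No measurement at hand accounts for these steps.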